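Oxan-4-yl for Cyclobutyl on an Amide Carbonyl

This account rests on a few compounds, and the source may have more. Where it says the series, first, only, none or still open, it means among the compounds named here.

Compound 1 `CCn1c(-c2cnc(C)nc2)nc2c(N[C@H]3CCN(C(=O)C4CCC4)C3)ncnc21` was tested in an ADME assay (Rattus norvegicus, strain Wistar Han) for metabolic stability (a higher number here means that the compound lasts longer, a lower number that the compound disappears faster), and gives 0.6 h. Two companions built on a core that differs from compound 1 in more than one place were measured alongside it: compound 2 `CCn1c(-c2ccc(C(F)(F)F)nc2)nc2c(O[C@H]3CCN(C(=O)c4cocn4)C3)ncnc21` gives 6 h, and compound 3 `CCn1c(-c2ccc(C(F)(F)F)nc2)nc2c(O[C@H]3CCN(C(=O)[C@H]4C[C@@H](OC)C4)C3)ncnc21` gives 3.3 h. Compound 1 therefore stands lowest of the three, with compound 3 nearest and compound 2 furthest, both beyond the scatter.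

Compound 4 `CCn1c(-c2cnc(C)nc2)nc2c(N[C@H]3CCN(C(=O)C4CCOCC4)C3)ncnc21` is the next step from compound 1, and the structural change is oxan-4-yl in place of cyclobutyl on a carbonyl carbon. Among the compounds with values here, the only measured step that also changes the group on a carbonyl carbon is a 1.8-fold lower number from compound 2 to compound 3 (0.26 log units; within the scatter), which stayed within the scatter even though it swapped an aromatic group for a saturated ring. Within the data shown here, that step compares a different pair of groups on a different core, so it is only a loose guide; no measured step exchanges cyclobutyl for oxan-4-yl. The expectation is therefore a step no larger than the scatter, if anything a slight rise: the estimated step is a 1.5-fold higher number from compound 1 to compound 4 (0.18 log units; within the scatter). On this basis compound 4 is expected to give 0.9 h, with a range from 0.4 h to 2 h.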

Compound 4, half-life: 1.4 h
Compound 4: middle estimate off by 1.6-fold (0.19 log units), on the low side; the range from low to high includes it.
By their numbers in this assay, from the lowest: compound 1; then compound 4; then compounds 3 and 2 (each within the scatter of the next).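

On the carbonyl carbon of the core of compound 1, replacing one non-aromatic ring with another changes the half-life in this assay by a 2.3-fold higher number from compound 1 to compound 4 (0.37 log units; beyond the scatter), although the step is modest and compound 4 keeps everything else in that core unchanged. The only earlier step at a carbonyl carbon, a 1.8-fold lower number from compound 2 to compound 3 (0.26 log units; within the scatter), stayed within the scatter on a different core and exchanged a different pair of groups, so this is the first shown change of this group that moves the number beyond the scatter. The exchange replaces a four-membered carbon ring with a six-membered ring that holds one oxygen and one hydrogen-bond acceptor, but no measurement here explains why the number rises.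

Ring size and the ring oxygen change together in this single step, so the compounds shown cannot separate them, and cyclohexyl on the same carbonyl carbon would be the direct comparison with oxan-4-yl. On these data alone, it also remains open whether oxan-4-yl would give a similar step on the core shared by compound 2 and compound 3.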